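A few compounds are considered here, and "the series" means these few. Any claim that something is new, unique, unknown or untested is made for them only; others in the source may bear on it.

Compound 1 `Nc1ccc(S(=O)(=O)N2CCN(c3ncc(C(O)(C(F)(F)F)C(F)(F)F)cc3-c3ccoc3)CC2)cn1`: 57 mL.min-1.g-1
Compound 2 `Nc1ccc(S(=O)(=O)N2CCN(c3ncc(C(O)(C(F)(F)F)C(F)(F)F)cc3-c3cccnc3)CC2)cn1`: 20 mL.min-1.g-1
Compound 3 `Nc1ccc(S(=O)(=O)N2CCN(c3ncc(C(O)(C(F)(F)F)C(F)(F)F)cc3-c3cnccc3F)CC2)cn1`: 22 mL.min-1.g-1

In an ADME assay (liver) for metabolic stability, with Liver microsome (Rattus norvegicus) as the target, using microsomes and NADPH, with a stated time of 30 min, tested at 1 uM (a higher number here means faster removal of the compound, a lower number slower removal), compound 3 stands with compound 2 in the lower pair of the series. Adding the fluoro group gives a 1.1-fold higher number from compound 2 to compound 3 (0.04 log units; within the scatter), whereas replacing furan-3-yl with 4-fluoropyridin-3-yl gives a 2.6-fold lower number from compound 1 to compound 3 (0.41 log units; beyond the scatter). The change from furan-3-yl to pyridin-3-yl gives a similar modest result, a 2.9-fold lower number from compound 1 to compound 2 (0.45 log units; beyond the scatter).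

The next compound is compound 4 `COc1ccc(-c2cc(C(O)(C(F)(F)F)C(F)(F)F)cnc2N2CCN(S(=O)(=O)c3ccc(N)nc3)CC2)cn1`, with the change (6-methoxypyridin-3-yl in place of 4-fluoropyridin-3-yl on an aromatic carbon). Here, 6-methoxypyridin-3-yl stands in place of 4-fluoropyridin-3-yl on an aromatic carbon. Compound 4 keeps a pyridine ring, so the modest drops away from the furan compound offer little reason to expect a large move. Going by the values given here, the only measured change of a substituent on that ring, a 1.1-fold higher number from compound 2 to compound 3 (0.04 log units; within the scatter), stayed within the scatter, although no measured step involves a methoxy group. A step beyond the scatter is therefore not expected in this assay, with a slight upward drift allowed.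

The expected result is a 1.4-fold higher number from compound 3 to compound 4 (0.13 log units; within the scatter).

For compound 4, the estimated value is 30 mL.min-1.g-1, with an expected range of 14 mL.min-1.g-1 to 65 mL.min-1.g-1.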

Compound 4, intrinsic clearance in microsomes: 265 mL.min-1.g-1
The estimate for compound 4 lay 8.8-fold (0.95 log units) below the measured number, and the stated range ends below it.
By their numbers in this assay, from the lowest: compounds 2 and 3 (each within the scatter of the next); then compound 1; then compound 4.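

In this assay this place on the shared core proves sensitive to what the pyridine ring carries: methoxy in place of hydrogen gives a 13-fold higher number from compound 2 to compound 4 (1.12 log units; beyond the scatter), whereas fluoro in place of hydrogen gave only a 1.1-fold higher number from compound 2 to compound 3 (0.04 log units; within the scatter). The exchange of 4-fluoropyridin-3-yl for 6-methoxypyridin-3-yl gives a 12-fold higher number from compound 3 to compound 4 (1.08 log units; beyond the scatter), and the exchange of furan-3-yl for 6-methoxypyridin-3-yl gives a 4.6-fold higher number from compound 1 to compound 4 (0.67 log units; beyond the scatter), so compound 4 goes against the pairing of a pyridine ring with the lower numbers seen in compound 2 and compound 3. Nothing available explains this rise.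

The compounds shown leave open whether the rise belongs to the methoxy group alone or would also come with other groups on that ring. A methyl group, a hydroxy group or an amine in its place would test this.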